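From nitro to ethoxy: a small step expected

The source may hold more compounds than are shown below. What is called first, only, known or untested is meant among the compounds shown, and "the series" means these compounds.

- compound 1 `O=C(CSc1nnc(COc2ccc3c(c2)CCCC3)o1)Nc1nc2ccc(Cl)cc2s1` gives 263000 nM
- compound 2 `O=C(CSc1nnc(COc2ccc3c(c2)CCCC3)o1)Nc1nc2ccc([N+](=O)[O-])cc2s1` gives 233000 nM

In a functional assay on A549 cells (Homo sapiens) for cytotoxicity, read by MTT assay, with a stated time of 24 h (a higher number here means a weaker inhibitor, a lower number a stronger inhibitor), the two measured compounds sit level, and compound 2 cannot be separated from compound 1 on these numbers. Compound 3 `CCOc1ccc2nc(NC(=O)CSc3nnc(COc4ccc5c(c4)CCCC5)o3)sc2c1` has not yet been measured. It differs from compound 2 in one place, with ethoxy in place of nitro on an aromatic carbon. Going by the values given here, no measured compound carries ethoxy, so the single measured step, nitro in place of chloro on an aromatic carbon, is the only guide. That step shows a 1.1-fold lower number from compound 1 to compound 2 (0.05 log units; within the scatter) and offers no sign of a trend. Going by it, no change beyond the scatter is expected in this assay in either direction, and compound 3 is expected to stay close to compound 2 at 233000 nM, though one step is thin evidence for a new group. The estimated step is a 1.0-fold higher number from compound 2 to compound 3 (0.01 log units; within the scatter), which is none beyond the scatter. For compound 3 the estimated value is 240000 nM, with an expected range from 110000 nM to 500000 nM.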

Compound 3, half-maximal inhibitory concentration: 283000 nM
For compound 3 the middle estimate is 1.2-fold (0.07 log units) below the measured one; the measured number falls inside the stated range.
By their numbers in this assay, from the lowest: compounds 2, 1 and 3 (each within the scatter of the next).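

Ethoxy in place of nitro on this aromatic carbon gives a 1.2-fold higher number from compound 2 to compound 3 (0.08 log units; within the scatter) in this assay, and ethoxy in place of chloro gives a 1.1-fold higher number from compound 1 to compound 3 (0.03 log units; within the scatter). The earlier pair had tested only chloro and nitro here, whereas ethoxy brings a group with a carbon chain to the same carbon, and compound 1, compound 2 and compound 3 still cannot be separated on these numbers, so a third substituent adds no sign of a trend at this position in this assay. No supporting evidence is available that bears on this result.

The compounds shown leave open whether an amine, a carboxylic acid or a longer alkoxy chain on this aromatic carbon would shift the number beyond the scatter, or whether this position simply makes little difference across a wider range of groups. They also leave open whether a change elsewhere in the shared core would move the number in this assay, as compound 1, compound 2 and compound 3 differ only at this one place.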